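Series notes: chloro in place of nitro on compound 1

The source may hold more compounds than are shown below. What is called first, only, known or untested is meant among the compounds shown, and "the series" means these compounds.

Measured so far:
compound 1 `Cc1cccc(Cn2c(CN3CCN(C(=O)c4ccc([N+](=O)[O-])cc4)CC3)nc3ccccc32)c1`: 24.3%
compound 2 `O=C(C1CC1)N1CCN(Cc2nc3ccccc3n2Cc2ccccc2F)CC1`: 40.7%
compound 3 `CC(C)CCn1c(OC2CCN(C(=O)c3ccco3)CC2)nc2ccccc21`: 30.8%

In an assay on isolated protein for inhibition of aldehyde dehydrogenase 1A1 (Homo sapiens), read by spectrophotometry, tested at 10 uM (a lower number here means less inhibition, a higher number more inhibition at the concentration tested (going by the name of the read-out)), compound 1 gives 24.3%, the smallest of the three numbers in hand. Compound 3 gives 30.8%, a number within the scatter of compound 1, so the two are not separated. Compound 2 gives 40.7%, which lies beyond the scatter above compound 1. Within the data shown here, the three measured compounds differ from one another in several places at once, so no single-point step is available among them.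

Compound 4 `Cc1cccc(Cn2c(CN3CCN(C(=O)c4ccc(Cl)cc4)CC3)nc3ccccc32)c1` differs from compound 1 in one place: chloro in place of nitro on an aromatic carbon. Among the measured compounds shown here, no measured pair shows what this kind of exchange does in this assay, and the shared core and the rest of compound 1 are kept. The step of a number 2.7 percentage points higher from compound 1 to compound 4 (within the scatter) is therefore expected to be small, in no firm direction, and not beyond the scatter. Compound 4 is expected to give 27% in this assay, with a range from 10% to 48%.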

Compound 4, a percentage reported as inhibition, at one concentration (the size of the read-out at that concentration, not a potency): 23.2%
The estimate for compound 4 lay 3.8 percentage points above the measured number; low and high end bracket the measured number.
By their numbers in this assay, from the lowest: compounds 4, 1, 3 and 2 (each within the scatter of the next, the first and the last beyond it).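

In this assay chloro in place of nitro on an aromatic carbon para to a large group gives a number 1.1 percentage points lower from compound 1 to compound 4 (within the scatter) and so leaves the two compounds unseparated. Among these compounds, this is the first single-point step, and it shows that this position accepts a nitro, with 2 hydrogen-bond acceptors, or a chloro, with 0, without a readable shift in the number. No supporting measurement bears on why the exchange leaves the number in place.

Going by these compounds, whether an amine, a carboxylic acid or a longer chain at this position would move the number beyond the scatter remains open. Also open, on these data alone, is whether chloro in place of nitro stays this small a step when the rest of the molecule is changed.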